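This account rests on a few compounds, and the source may have more. Where it says the series, first, only, none or still open, it means among the compounds named here.

Measured compounds:
Compound 1, `CC1=CC[C@@H]([C@@](C)(O)CCCC(C)(C)NC(=S)N/N=C\c2ccccc2)CC1`: in a functional assay on OVCAR-3 cells (Homo sapiens) for cytotoxicity, read by sulforhodamine B assay (on this read-out lower numbers stand for stronger inhibition of growth and higher numbers for weaker inhibition of growth), compound 1 gives 6970 nM.
Compound 2, `CC1=CC[C@@H]([C@@](C)(O)CCCC(C)(C)NC(=S)N/N=C\c2ccc(C)cc2)CC1`: compound 2 gives 6020 nM.
Compound 3, `CC1=CC[C@@H]([C@@](C)(O)CCCC(C)(C)NC(=S)N/N=C\c2ccccc2[N+](=O)[O-])CC1`: compound 3 gives 7390 nM.

Compound 3 carries the highest of the three numbers, but the differences around it are small: from compound 1 to compound 3 the step is a 1.1-fold higher number from compound 1 to compound 3 (0.03 log units; within the scatter), and from compound 2 to compound 3 it is a 1.2-fold higher number from compound 2 to compound 3 (0.09 log units; within the scatter), both within the scatter. The step from compound 1 to compound 2, a 1.2-fold lower number from compound 1 to compound 2 (0.06 log units; within the scatter), is likewise within the scatter, so the three measured compounds cannot be ordered.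

Compound 4, `CC1=CC[C@@H]([C@@](C)(O)CCCC(C)(C)NC(=S)N/N=C\c2ccccc2Cl)CC1`, differs from compound 3 in one place: chloro in place of nitro on an aromatic carbon. Within the data shown here, no measured step involves a chloro group, so the only steps that bear on this change are those at the same part of the molecule, and every one of them stayed within the scatter. Because the step of a 1.1-fold higher number from compound 1 to compound 3 (0.03 log units; within the scatter) shows that placing the nitro group there left the number essentially unchanged, compound 4 is expected to give a number close to that of compound 3, with the estimated step of a 1.1-fold lower number from compound 3 to compound 4 (0.02 log units; within the scatter), in no direction beyond the scatter. The estimate for compound 4 is therefore 7000 nM, between 3500 nM and 14000 nM.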

Compound 4, concentration for 50% growth inhibition: 42000 nM
For compound 4 the middle estimate is 6.0-fold (0.78 log units) below the measured one, outside the stated range (above it).
By their numbers in this assay, from the lowest: compounds 2, 1 and 3 (each within the scatter of the next); then compound 4.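

Before compound 4, every change on this aromatic ring stayed within the scatter, so the ring appeared to tolerate substitution; the 2-chlorophenyl group is the first change to move the number in this assay beyond it, with a 6.0-fold higher number from compound 1 to compound 4 (0.78 log units; beyond the scatter) and a 7.0-fold higher number from compound 2 to compound 4 (0.84 log units; beyond the scatter) as its steps from the unsubstituted and 4-methylphenyl compounds. The position itself therefore does not accept every group alike: on the same aromatic carbon, ortho to a large group, nitro stays within the scatter of hydrogen, whereas chloro gives a 5.7-fold higher number from compound 3 to compound 4 (0.75 log units; beyond the scatter) and so weaker inhibition of growth than nitro. Nothing in the available data accounts for this difference between chloro and nitro at this place.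

From the compounds shown here alone, whether fluoro, bromo or methoxy on this carbon would behave like chloro or like nitro remains open, so the two results cannot yet be extended to a trend across groups. Also open, going by these compounds, is whether chloro on another carbon of the same ring would give a similar step, or whether the step belongs to this place alone.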